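Working notes: fluoro added to the pyridin-4-yl group

This account rests on a few compounds, and the source may have more. Where it says the series, first, only, none or still open, it means among the compounds named here.

Measured so far:
- Compound 1 `CS(=O)(=O)Nc1cccc(-c2nc(C(c3ccc(F)cc3)c3ccc(F)cc3)sc2CC(=O)O)c1`; in an in vitro functional assay on HEK285-7 cells for antagonist activity at prostaglandin D2 receptor 2 (Homo sapiens), read by BRET and beta-arrestin recruitment (on this read-out lower numbers stand for stronger inhibition and higher numbers for weaker inhibition), compound 1 gives 370 nM.
- Compound 2 `O=C(O)Cc1sc(C(c2ccc(F)cc2)c2ccc(F)cc2)nc1-c1ccncc1`; in this assay compound 2 gives 40 nM.

Among the compounds with values here, compound 2 holds the lowest number of the two; the only step recorded is a 9.3-fold lower number from compound 1 to compound 2 (0.97 log units; beyond the scatter), which moves beyond the scatter.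

Compound 3 `O=C(O)Cc1sc(C(c2ccc(F)cc2)c2ccc(F)cc2)nc1-c1ccnc(F)c1` differs from compound 2 by fluoro in place of hydrogen on an aromatic carbon. Within the data shown here, no measured step touches a change of this kind: the one step, from compound 1 to compound 2, exchanges the whole aryl group rather than adding a single substituent, so it gives no direct guide to the size or direction of the present change. With nothing to point either way, the expectation for compound 3 in this assay is a step no larger than the usual scatter, a 1.3-fold higher number from compound 2 to compound 3 (0.10 log units; within the scatter). Compound 3 is therefore estimated at 50 nM, with a range from 15 nM to 160 nM.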

Compound 3, half-maximal inhibitory concentration: 4.7 nM
The estimate for compound 3 lay 11-fold (1.03 log units) above the measured number, outside the stated range (below it).
By their numbers in this assay, from the lowest: compound 3; then compound 2; then compound 1.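

In this assay, a single fluoro on an aromatic carbon next to the ring nitrogen gives an 8.5-fold lower number from compound 2 to compound 3 (0.93 log units; beyond the scatter) and so lies beyond the scatter, which shows that this position of the pyridin-4-yl group is sensitive to the addition of one heavy atom. Against the sulfonamide-bearing aryl group, 2-fluoropyridin-4-yl gives a 79-fold lower number from compound 1 to compound 3 (1.90 log units; beyond the scatter) and so extends the gain already seen with the unsubstituted pyridin-4-yl group. No measurement on hand explains why this fluoro lowers the number.

Whether the gain is particular to fluoro remains open, since the compounds shown do not say how chloro, methyl or methoxy would read at the same place. Also open, from the compounds shown here alone, is whether a second fluoro on the same ring would lower the number further or raise it.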